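The source may hold more compounds than are shown below. What is called first, only, known or untested is meant among the compounds shown, and "the series" means these compounds.

Measured so far in an assay on HEK293 cells for inhibition of Steryl-sulfatase (Homo sapiens), tested at 1 uM; on this read-out higher numbers stand for a stronger effect at the one concentration tested and lower numbers for a weaker effect:
compound 1 `CN(C)CCN(CCN(C)C)c1ccc(C(=O)N2CCc3ccc(OS(N)(=O)=O)cc3C2)cc1` gives 15.9%
compound 2 `NS(=O)(=O)Oc1ccc2c(c1)CN(C(=O)c1ccc(N3CCCCC3)cc1)CC2` gives 38.3%
compound 3 `CCN(Cc1ccc(F)cc1)c1ccc(C(=O)N2CCc3ccc(OS(N)(=O)=O)cc3C2)cc1` gives 91.2%

Compound 3 stands highest of the three; the step of a number 52.9 percentage points higher from compound 2 to compound 3 (beyond the scatter) and the step of a number 75.3 percentage points higher from compound 1 to compound 3 (beyond the scatter) are both beyond the scatter, and the step of a number 22.4 percentage points higher from compound 1 to compound 2 (beyond the scatter) is smaller. Compound 4 `CN(CCCN1CCCCC1)c1ccc(C(=O)N2CCc3ccc(OS(N)(=O)=O)cc3C2)cc1` differs from compound 3 in one place: methyl(3-(piperidin-1-yl)propyl)amino in place of ethyl(4-fluorobenzyl)amino on an aromatic carbon. The two steps leading up to compound 3 both bear on this change, since each replaced an amino group without a 4-fluorobenzyl with ethyl(4-fluorobenzyl)amino and rose strongly. Compound 4 walks that move back, and its entering group carries a piperidin-1-yl as the group of compound 2 does. A large fall is therefore expected, a number 56.2 percentage points lower from compound 3 to compound 4 (beyond the scatter), towards the neighbourhood of compound 2. Compound 4 is estimated at 35%, with a range from 15% to 60%.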

Compound 4, a percentage reported as inhibition, at one concentration (the size of the read-out at that concentration, not a potency): 40.7%
For compound 4 the middle estimate is 5.7 percentage points below the measured one; measured number inside the range.
By their numbers in this assay, from the lowest: compound 1; then compounds 2 and 4 (each within the scatter of the next); then compound 3.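

Although the leaving and entering groups have the same count of heavy atoms, methyl(3-(piperidin-1-yl)propyl)amino in place of ethyl(4-fluorobenzyl)amino on the aromatic carbon gives a number 50.5 percentage points lower from compound 3 to compound 4 (beyond the scatter) in this assay, so that count does not preserve the high reading of compound 3. Carrying the piperidine ring on a propyl chain makes no readable difference, with a number 2.4 percentage points higher from compound 2 to compound 4 (within the scatter), and a number 24.8 percentage points higher from compound 1 to compound 4 (beyond the scatter) is a modest step. Nothing measured here accounts for these differences.

Going by these compounds, whether the reading of compound 3 depends on the fluorine or on the benzyl ring remains open, as does how a plain benzyl or a 4-methoxybenzyl group would read.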